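The compounds below may be only part of what the source reports. "The series", "measured", "known", "first", "only" and "open" are said of these compounds alone.

Measured so far:
compound 1 `Cc1cccc(NC(=O)Nc2nnc(Sc3ncnc4scc(-c5ccncc5)c34)s2)c1` — 20700 nM
compound 2 `O=C(Nc1ccc(F)cc1)Nc1nnc(Sc2ncnc3scc(-c4ccncc4)c23)s1` — 31700 nM
compound 3 `O=C(Nc1ccc(Cl)c(Cl)c1)Nc1nnc(Sc2ncnc3scc(-c4ccncc4)c23)s1` — 61900 nM

All three were tested in a functional assay on HepG2 cells (Homo sapiens) for antiproliferative activity, read by MTT assay, with a stated time of 48 h; on this read-out higher numbers stand for weaker inhibition and lower numbers for stronger inhibition. They share one core and differ only in the aryl group carried on the amide-type nitrogen. Compound 3 gives the highest number of the three: one step, a 2.0-fold higher number from compound 2 to compound 3 (0.29 log units; within the scatter), stays within the scatter, while the other, a 3.0-fold higher number from compound 1 to compound 3 (0.48 log units; beyond the scatter), lies beyond it, so compound 3 is the weakest inhibitor seen here relative to compound 1 only.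

Compound 4 `COc1cccc(NC(=O)Nc2nnc(Sc3ncnc4scc(-c5ccncc5)c34)s2)c1` is not yet measured. It differs from compound 3 by 3-methoxyphenyl in place of 3,4-dichlorophenyl on an amide-type nitrogen.

For the measured compounds named here, two measured steps bear on this change, both replacing one aryl group on the same nitrogen with another. The step of a 1.5-fold higher number from compound 1 to compound 2 (0.19 log units; within the scatter) is within the scatter; the step of a 3.0-fold higher number from compound 1 to compound 3 (0.48 log units; beyond the scatter) is modest and beyond it. The compound with a single small group on its phenyl ring, compound 1, gave the lowest number, and compound 4 likewise carries a single small group, so a return toward that level is expected, meaning a lower number than compound 3 by a step estimated as a 2.5-fold lower number from compound 3 to compound 4 (0.39 log units; beyond the scatter). Compound 4 is therefore estimated at 25000 nM, within the range 10000 nM to 60000 nM.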

Compound 4, half-maximal inhibitory concentration: 28400 nM
The estimate for compound 4 lay 1.1-fold (0.06 log units) below the measured number; measured number inside the range.
By their numbers in this assay, from the lowest: compounds 1, 4, 2 and 3 (each within the scatter of the next, the first and the last beyond it).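

Among the four compounds, only compound 4 carries an oxygen on this aryl group and so a hydrogen-bond acceptor on the amide-type nitrogen, and in this assay the change from 3,4-dichlorophenyl to 3-methoxyphenyl gives a 2.2-fold lower number from compound 3 to compound 4 (0.34 log units; beyond the scatter) as a modest step. That step does not set the new group apart from the other aryl groups with a single substituent, since a 1.1-fold lower number from compound 2 to compound 4 (0.05 log units; within the scatter) and a 1.4-fold higher number from compound 1 to compound 4 (0.14 log units; within the scatter) both stay within the scatter, so 3-methylphenyl, 4-fluorophenyl and 3-methoxyphenyl cannot be told apart on this read-out, while compound 3 lies beyond the scatter from compound 1 and compound 4 but not from compound 2. No measurement shown here accounts for these differences.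

As far as these compounds go, all the numbers shown sit in a narrow band, so it remains open whether any group on this nitrogen can move the antiproliferative read-out much further, for example a phenyl ring bearing an amine or a carboxylic acid, or a longer alkyl chain in place of the aryl ring. The compounds shown also vary only this one place, so they say nothing about how changes elsewhere on the shared core would behave.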